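Methoxy added to the shared core: compound 2 to compound 3

A few compounds are considered here, and "the series" means these few. Any claim that something is new, unique, unknown or untested is made for them only; others in the source may bear on it.

Two members of the series have been measured in a functional assay on cells (Leukemia cell, Homo sapiens) for cytotoxicity, with a stated time of 48 h (a higher number here means a weaker inhibitor of growth, a lower number a stronger inhibitor of growth), so far. Compound 1 `COc1cc2c(/C=C3/C(=O)Nc4cccc(Cl)c43)c(Cl)n(Cc3cc(OC)c(OC)c(OC)c3)c2cc1C` carries the bulkier substitution pattern and in this assay gives 2450 nM. Compound 2 `COc1c(/C=C2/C(=O)Nc3ccccc32)c2ccccc2n1-c1ccccc1` is the simpler member, and in this assay compound 2 gives 520 nM. On these two numbers compound 2 stands with the lower value, and the gap between it and compound 1 lies beyond the usual scatter of repeated measurements, so compound 2 is the stronger growth inhibitor of the pair.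

The next step keeps compound 2 intact apart from one change: compound 3 `COc1ccc2c(c1)/C(=C\c1c(OC)n(-c3ccccc3)c3ccccc13)C(=O)N2` has methoxy in place of hydrogen on an aromatic carbon. Within the data shown here, no pair of measured compounds differing only in this way exists, so there is no measured step to lean on. A single methoxy added at this place is expected to move this assay little; the step from a 1.2-fold lower number from compound 2 to compound 3 (0.06 log units; within the scatter) is estimated to stay within the scatter, with no clear direction. Compound 3 is accordingly expected to give about 450 nM in this assay, with a plausible span from 150 nM to 1500 nM.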

Compound 3, concentration for 50% growth inhibition: 760 nM
Estimate against measurement, compound 3: 1.7-fold (0.23 log units) below; the measured number falls inside the stated range.
By their numbers in this assay, from the lowest: compounds 2 and 3 (each within the scatter of the next); then compound 1.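

In this assay, methoxy in place of hydrogen on an aromatic carbon gives a 1.5-fold higher number from compound 2 to compound 3 (0.16 log units; within the scatter), so the pair cannot be told apart and this place on the six-membered aromatic ring of carbon only accepts a methoxy without a readable shift in growth inhibition. Among these compounds, this is the first measured step that changes one place alone, whereas compound 1 differs from compound 2 in more than one place and could not isolate the contribution of any single group. Nothing available beyond these growth-inhibition numbers bears on the reason for this result.

Among the compounds shown here, the single step leaves open whether a larger or differently charged group, such as an amine or a carboxylic acid, would also leave the number within the scatter at this aromatic carbon. It also leaves open whether the same methoxy would behave in the same way on another carbon of this ring, or on the shared core of a compound with a different group on the ring nitrogen.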